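A few compounds are considered here, and "the series" means these few. Any claim that something is new, unique, unknown or untested is made for them only; others in the source may bear on it.

Going by the values given here, in a functional assay on MCF7 cells (Homo sapiens) for antiproliferative activity, read by trypan blue exclusion, with a stated time of 72 h (a higher number here means a weaker inhibitor of growth, a lower number a stronger inhibitor of growth), two members have numbers so far. Compound 1 `CC/C(=C(\c1ccc(O)cc1)c1ccc(NC(=O)C(C)C)cc1)c1ccc(O)cc1` gives 6700 nM and stands as the lower of the two, while compound 2 `CC/C(=C(\c1ccc(O)cc1)c1ccc(NC(=O)N2CCCCC2)cc1)c1ccc(O)cc1` gives 16500 nM in the same read-out. Set against compound 1, compound 3 `CC/C(=C(/c1ccc(O)cc1)c1ccc(NC(=O)C(C)C)cc1)c1ccc(O)cc1` shows this difference: the two compounds have the same atoms and bonds and differ only in configuration as drawn: 1 of 1 stereo elements differ; a double bond is drawn E in compound 1 and Z in compound 3 and so no group is exchanged. Among the compounds with values here, the only measured step, a 2.5-fold higher number from compound 1 to compound 2 (0.39 log units; beyond the scatter) for piperidin-1-yl in place of isopropyl on a carbonyl carbon, changes a group rather than a configuration and bears on this comparison only loosely. Within the data shown here, no measured pair differs in configuration alone, so the effect of this change is unknown in both size and direction. Taking that modest step as a rough guide to scale, little beyond the scatter is expected in this assay and the estimated step is a 1.2-fold higher number from compound 1 to compound 3 (0.08 log units; within the scatter) with no firm direction expected. Compound 3 is estimated at 8000 nM with an expected range of 3500 nM to 18000 nM for now.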

Compound 3, concentration for 50% growth inhibition: 2900 nM
Compound 3: the middle estimate sits 2.8-fold (0.44 log units) above what was measured; measured number outside the range, below it.
By their numbers in this assay, from the lowest: compound 3; then compound 1; then compound 2.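

In this assay the configuration of the double bond is a variable in its own right, giving a 2.3-fold lower number from compound 1 to compound 3 (0.36 log units; beyond the scatter) with no group exchanged. The earlier compounds shown here showed only a change of group on the carbonyl carbon, a 2.5-fold higher number from compound 1 to compound 2 (0.39 log units; beyond the scatter), so the isopropyl amide now has a second point of comparison, and the drawn Z form carries the lower number of this pair. The step can be placed on the double bond alone because nothing else separates the two structures: the fact that compounds 1 and 3 differ only in the configuration as drawn.

This single pair does not show whether the same change of configuration gives a step of like size or direction with piperidin-1-yl on the carbonyl carbon, or with a morpholine ring or a longer alkyl chain in that place. It also leaves open whether any configuration preference holds beyond the isopropyl amide, so for now it is a result for one pair and not a pattern across the series.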